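The source may report more compounds than this note shows. Statements on the series, on what has been measured and on what is new or still open speak of the compounds shown alone.

Compound 1, `CCOc1nc(-c2nc3ccccc3n2C)cc(-c2ccccc2)c1C#N`, in a functional assay on aorta (Rattus norvegicus, strain Wister) (a higher number here means a weaker inhibitor, a lower number a stronger inhibitor), gives 364000 nM.
Compound 2, `CCOc1nc(-c2nc3ccccc3n2C)cc(-c2ccc(Cl)cc2Cl)c1C#N`, in this assay gives 305000 nM.
Compound 3, `COc1ccc(-c2cc(-c3nc4ccccc4n3C)nc(OC)c2C#N)cc1`, in this assay gives 210000 nM.

All three compounds share the same core and differ only in the aryl group attached to it and in the alkoxy group beside the nitrile. Compound 3 has the lowest of the three numbers, but the gaps to compound 2 and to compound 1 both lie within the scatter, so none of the three can be called stronger or weaker than the others. Within the data shown here, the one step between measured compounds that differ in a single place is a 1.2-fold lower number from compound 1 to compound 2 (0.08 log units; within the scatter), and it too stays within the scatter.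

Compound 4, `CCOc1nc(-c2nc3ccccc3n2C)cc(-c2ccc(OC)cc2)c1C#N`, is the next compound. It differs from compound 3 by methyl in place of hydrogen on a saturated chain carbon bound to an oxygen on an aromatic ring. Among the measured compounds shown here, no measured pair isolates this exact change, but compound 1 and compound 2 carry the ethoxy group while compound 3 carries the methoxy group, and their values sit within the scatter of one another. On that basis the step of a 1.0-fold higher number from compound 3 to compound 4 (0.02 log units; within the scatter) is expected to lie within the scatter as well. The value expected for compound 4 is 220000 nM, with a range from 100000 nM to 480000 nM.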

Compound 4, half-maximal inhibitory concentration: 436000 nM
Estimate against measurement, compound 4: 2.0-fold (0.30 log units) below, within the range that was stated.
By their numbers in this assay, from the lowest: compounds 3, 2, 1 and 4 (each within the scatter of the next, the first and the last beyond it).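

Methyl in place of hydrogen on the saturated chain carbon bound to the oxygen, which turns methoxy into ethoxy, gives in this assay a 2.1-fold higher number from compound 3 to compound 4 (0.32 log units; beyond the scatter), so this position, which the earlier compounds could not test on its own, can move the number modestly beyond the scatter when the aryl group is 4-methoxyphenyl. With ethoxy held in place, neither aryl change separates the compounds: methoxy in place of hydrogen on an aromatic carbon gives a 1.2-fold higher number from compound 1 to compound 4 (0.08 log units; within the scatter), and 4-methoxyphenyl in place of 2,4-dichlorophenyl gives a 1.4-fold higher number from compound 2 to compound 4 (0.16 log units; within the scatter), both within the scatter. Nothing shown here explains why one added methyl registers while these larger aryl changes do not.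

As far as these compounds go, this methoxy and ethoxy pair exists only for the 4-methoxyphenyl group, so whether the same step holds with phenyl or 2,4-dichlorophenyl remains open. From the compounds shown here alone, how a longer chain such as propoxy, or an amine on the same aromatic carbon in place of the alkoxy group, would read also remains open.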